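A few compounds are considered here, and "the series" means these few. Any claim that something is new, unique, unknown or untested is made for them only; others in the source may bear on it.

Of the compounds shown here, three that share one core have been measured in a physicochemical assay for lipophilicity, read by HPLC, measured as chromatographic lipophilicity, at pH 7.4; a lower number here means a more polar compound, a higher number a more lipophilic compound. Compound 1 `CC(C)(CN)C(=O)N1N=CCC1c1ccccc1` gives 1.4, compound 2 `O=C(c1ccccn1)N1N=CCC1c1ccccc1` gives 2.4, and compound 3 `O=C(C1CCOC1)N1N=CCC1c1ccccc1` gives 3. Among the measured compounds shown here, compound 3 stands highest of the three: the step of a number 1.60 log units higher from compound 1 to compound 3 (beyond the scatter) and the step of a number 0.60 log units higher from compound 2 to compound 3 (beyond the scatter) both lie beyond the scatter, so compound 3 is the most lipophilic compound measured so far.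

Compound 4 `CC(C)C(=O)N1N=CCC1c1ccccc1` is the next to be measured. It differs from compound 3 in one place: isopropyl in place of oxolan-3-yl on a carbonyl carbon.

For the measured compounds named here, none of the measured steps swaps a ring for an open chain at this position, so no close precedent exists. The two steps that lead up to compound 3 do show that the group on the carbonyl carbon can shift the number in this assay by modest to large amounts, but both of them remove quite different groups from what leaves here. Since the change both takes away the ring with its oxygen and puts in a smaller chain, the expected step in this assay is small and likely within the scatter. Starting from the value of compound 3, 3, compound 4 is estimated at 3.2, within a range from 2.7 to 3.7. This corresponds to an expected step of a number 0.20 log units higher from compound 3 to compound 4 (within the scatter).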

Compound 4, distribution coefficient: 4.4
Compound 4: the middle estimate sits 1.20 log units below what was measured; the measured number lies above the stated range.
By their numbers in this assay, from the lowest: compound 1; then compound 2; then compound 3; then compound 4.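

Swapping oxolan-3-yl for isopropyl on the carbonyl carbon removes the ring, its oxygen and its hydrogen-bond acceptor, and in this assay this gives a number 1.40 log units higher from compound 3 to compound 4 (beyond the scatter), which shows that a change between two small groups without net charge can produce a large step at this position. Among the compounds shown here, compound 4 also stands clearly apart from the compound carrying pyridin-2-yl, with a number 2.00 log units higher from compound 2 to compound 4 (beyond the scatter), and its steps to all three earlier compounds lie beyond the scatter, making it the most lipophilic compound measured so far. Hydrogen in place of aminomethyl on the saturated chain gives the widest step shown, a number 3.00 log units higher from compound 1 to compound 4 (beyond the scatter), while no measurement here accounts for the size of any of these steps.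

As far as these compounds go, the swap from compound 3 to compound 4 changes the ring, the oxygen and the number of heavy atoms all at once, so the share of each in the step remains open. A cyclopentyl group, which keeps a ring without the oxygen, and a methoxymethyl chain, which keeps an oxygen without a ring, would help separate these changes.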